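Chlorophenyl Position Change on a Shared Thioether Arm

The source may hold more compounds than are shown below. What is called first, only, known or untested is meant among the compounds shown, and "the series" means these compounds.

Compound 1 `COc1ccc(C2N=C(SCc3cccc(Cl)c3)NC(C)=C2C(=O)Nc2ccc(F)cc2)cc1OC`: 5.2%
Compound 2 `COc1ccc(C2N=C(SCc3ccc(Cl)cc3)NC(C)=C2C(=O)Nc2ccc(F)cc2)cc1OC`: 5.7%
Compound 3 `CC1=C(C(=O)Nc2ccc([N+](=O)[O-])cc2)C(c2ccc(Br)cc2)N=C(SCc2cccc(Cl)c2)N1`: 2.6%

In a functional assay on the whole organism (artery, strain albino) with Rattus norvegicus as the target, with a stated time of 30 min, at a dose of 10 mg/kg by the oral route (on this read-out higher numbers stand for more inhibition at the one dose given (going by the name of the read-out) and lower numbers for less inhibition), compound 1 gives 5.2% and compound 2 gives 5.7%. The change between them is 4-chlorophenyl in place of 3-chlorophenyl on a saturated chain carbon bound to a sulfur, and the step of a number 0.5 percentage points higher from compound 1 to compound 2 (within the scatter) shows it made no difference worth the name. Compound 3 gives 2.6% in this assay; the difference between the core of compound 3 and that of compound 1 is not broken down here. Compound 4 `CC1=C(C(=O)Nc2ccc([N+](=O)[O-])cc2)C(c2ccc(Br)cc2)N=C(SCc2ccc(Cl)cc2)N1` is not yet measured, and it differs from compound 3 by 4-chlorophenyl in place of 3-chlorophenyl on a saturated chain carbon bound to a sulfur, the same change that was seen from compound 1 to compound 2. Because the step of a number 0.5 percentage points higher from compound 1 to compound 2 (within the scatter) stayed within the scatter, compound 4 is expected to show a step of a number 0.5 percentage points higher from compound 3 to compound 4 (within the scatter) from compound 3. The estimate for compound 4 in this assay is therefore 3.1%, between -6% and 13%.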

Compound 4, a percentage reported as inhibition, in the whole organism at one dose (the size of the read-out at that dose, not a potency): 6.2%
Beside the measured number, compound 4's estimate is 3.1 percentage points below it; low and high end bracket the measured number.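

In this assay, 4-chlorophenyl in place of 3-chlorophenyl on a saturated chain carbon bound to a sulfur gives a number 3.6 percentage points higher from compound 3 to compound 4 (within the scatter), and set beside the earlier step on the other core it shows no difference: the same change on two cores in this assay, a number 0.5 percentage points higher (within the scatter) from compound 1 to compound 2 and a number 3.6 percentage points higher (within the scatter) from compound 3 to compound 4, 3.1 percentage points apart, within the scatter of two such steps This shows that the change stays within the scatter on both cores, so its small size carries from one core to the other. It does not show that the change alters inhibition on either core, and two cores at one dose are a narrow base for any wider rule.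

The compounds shown leave open whether another group at this place, such as an unsubstituted benzyl, a longer chain or an amine, would move the read-out beyond the scatter. On these data alone, the two cores differ in more than one place, and what each part contributes also stays open.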